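The compounds below may be only part of what the source reports. "The series", "measured", "known", "first", "only" and "open" are said of these compounds alone.

Measured in a functional assay on QGY-7703 cells (Homo sapiens) for cytotoxicity, read by MTT assay, with a stated time of 24 h; a higher number here means a weaker inhibitor, a lower number a stronger inhibitor:
- Compound 1 `CC(=O)Nc1ccc(S(=O)(=O)N2C/C(=C\c3ccc(C#N)cc3)C(=O)/C(=C/c3ccc(C#N)cc3)C2)cc1`: 3320 nM
- Compound 2 `N#Cc1ccc(/C=C2\CN(S(=O)(=O)c3ccc(F)cc3)C/C(=C\c3ccccc3F)C2=O)cc1`: 20100 nM
- Compound 3 `COc1cc(/C=C2\CN(S(=O)(=O)c3ccc(F)cc3)C/C(=C\c3ccccc3F)C2=O)cc(OC)c1OC`: 13300 nM

Compound 2, at 20100 nM, sits level with compound 3 within the scatter, and its number is well above that of compound 1 at 3320 nM.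

The change to compound 4 `CC(=O)Nc1ccc(S(=O)(=O)N2C/C(=C\c3ccc(C#N)cc3)C(=O)/C(=C/c3ccccc3F)C2)cc1` is acetamido in place of fluoro on an aromatic carbon, that is, 4-fluorophenyl to 4-acetamidophenyl.

Among the compounds with values here, no measured step isolates this change. Within the data shown here, the only single-place step, a 1.5-fold lower number from compound 2 to compound 3 (0.18 log units; within the scatter), replaces 4-cyanophenyl with 3,4,5-trimethoxyphenyl elsewhere on the molecule and so gives no direct size for this change. It does show one exchange at that other site that leaves the number within the scatter.

Compound 1 is the closest guide. It carries the same 4-acetamidophenyl as compound 4 and differs from it only on the other arm, where a second 4-cyanophenyl stands in place of the fluorophenyl. Compound 4 is therefore expected to lie nearer compound 1 than compound 2, though this rests on a single comparison.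

The expected change in this assay is a lower number, beyond the scatter, and the estimated step is a 3.7-fold lower number from compound 2 to compound 4 (0.56 log units; beyond the scatter).

For compound 4 the estimate is 5500 nM, with an expected range of 2200 nM to 14000 nM.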

Compound 4, half-maximal inhibitory concentration: 2050 nM
For compound 4 the middle estimate is 2.7-fold (0.43 log units) above the measured one; the measured number lies below the stated range.
By their numbers in this assay, from the lowest: compounds 4 and 1 (each within the scatter of the next); then compounds 3 and 2 (each within the scatter of the next).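

In this assay, within the data shown here, acetamido in place of fluoro, on an aromatic carbon para to a large group, gives a 9.8-fold lower number from compound 2 to compound 4 (0.99 log units; beyond the scatter), the only single-place change so far whose step lies beyond the scatter. With the 4-acetamidophenyl held constant, 2-fluorophenyl in place of 4-cyanophenyl on the other arm gives a 1.6-fold lower number from compound 1 to compound 4 (0.21 log units; within the scatter), so this arm exchange, like the one in a 1.5-fold lower number from compound 2 to compound 3 (0.18 log units; within the scatter), stays within the scatter, and among the steps shown only the change from 4-fluorophenyl to 4-acetamidophenyl moves the number beyond it. Nothing available on these compounds explains the size of this step.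

As far as these compounds go, the step from fluoro to acetamido rests on one pair, so it remains open whether it holds with other groups on the other arm, such as the 3,4,5-trimethoxyphenyl of compound 3. Also open, from the compounds shown here alone, is which part of the acetamido matters, and a free amine, a longer acyl chain such as propionamido, or a carboxylic acid at the same place would test whether the lower number persists.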